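The compounds below may be only part of what the source reports. "The series", "measured", "known", "first", "only" and "open" are said of these compounds alone.

Measured compounds:
compound 1 `O=C(CN1CC=CC[C@H](NC(=O)c2cc(Cl)ccc2Cl)C1=O)N[C@H]1CC(=O)OC1O` – 71 nM
compound 2 `CC1=CC[C@H](NC(=O)c2ccc3ccccc3c2)C(=O)N(CC(=O)N[C@H]2CC(=O)OC2O)C1` – 153 nM
compound 3 `O=C[C@H](CC(=O)O)NC(=O)[C@@H]1COC[C@@H]2C/C=C\C[C@H](NC(=O)c3nccc4ccccc34)C(=O)N21` – 182 nM

All three numbers come from a functional assay on THP-1 cells (Homo sapiens) for inhibition; on this read-out lower numbers stand for stronger inhibition and higher numbers for weaker inhibition. Compound 1 holds the lowest number of the three; its gaps to compound 2 and to compound 3 both lie beyond the scatter, so on these values compound 1 is the most potent of the set. Compound 2 and compound 3 sit within the scatter of each other, so no order is read between them.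

Compound 4 `O=C(CN1CC=CC[C@H](NC(=O)c2cc3ccccc3s2)C1=O)N[C@H]1CC(=O)OC1O` is not yet measured in this assay. It keeps the core of compound 1 and changes only the amide aryl group: 1-benzothiophen-2-yl in place of 2,5-dichlorophenyl on a carbonyl carbon. What leaves is a six-membered aromatic ring of carbon only carrying two chlorine atoms; what enters is a fused pair of rings, one five-membered aromatic ring with one hetero atom and one six-membered aromatic ring of carbon only, on the same carbonyl carbon next to the amide-type nitrogen.

Among the measured compounds shown here, nothing in the set pairs a single-ring aryl amide with its fused-ring counterpart on one core, so no measured step gives the size directly. The two fused-ring amides present, compound 2 and compound 3, both carry higher numbers than compound 1, on different cores. The expectation is therefore a modest rise in the number, of about a 1.5-fold higher number from compound 1 to compound 4 (0.19 log units; within the scatter), with a fair chance it stays within the scatter. Compound 4 is estimated at 110 nM, in the range 40 nM to 300 nM.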

Compound 4, half-maximal inhibitory concentration: 712 nM
Beside the measured number, compound 4's estimate is 6.5-fold (0.81 log units) below it; measured number above the stated range.
By their numbers in this assay, from the lowest: compound 1; then compounds 2 and 3 (each within the scatter of the next); then compound 4.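

In this assay, 1-benzothiophen-2-yl in place of 2,5-dichlorophenyl on the carbonyl carbon gives a 10-fold higher number from compound 1 to compound 4 (1.00 log units; beyond the scatter) on the shared core. Among the compounds shown here, this is the first step with only one place changed, and it shows that the read-out responds strongly to the amide aryl group, which the earlier compounds, differing in several places, could not show. With the core of compound 1 held fixed, the 2,5-dichlorophenyl amide is the stronger inhibitor of this pair, and nothing at hand gives a measured reason for the step.

For the compounds shown here, the single step changes the ring count, the ring type and the two chlorine atoms together, so it does not separate the loss of the chlorine atoms from the gain of the fused pair of rings. An unsubstituted phenyl on the same carbonyl carbon would address the chlorine atoms alone, and 1-benzofuran-2-yl, with oxygen in place of sulfur, would test whether the step depends on the sulfur atom or on the fused pair of rings.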